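This account rests on a few compounds, and the source may have more. Where it says the series, first, only, none or still open, it means among the compounds named here.

Compound 1 `O=C(Nc1nc2ccc(Cl)cc2s1)c1cn(-c2ccccc2)nc1-c1ccccc1` gives 7670 nM in a functional assay on A549 cells (Homo sapiens) for cytotoxicity, read by MTT assay, with a stated time of 72 h; a lower number here means a stronger inhibitor, a higher number a weaker inhibitor. Compound 2 `COc1ccc2nc(NC(=O)c3cn(-c4ccccc4)nc3-c3ccccc3)sc2c1` reaches only a limit of this assay, > 50000 nM, which is the limit of > 50000 nM in this assay, at which 1 of the 3 values shown sits. The change from compound 1 to compound 2 is methoxy in place of chloro on an aromatic carbon, and it brought an at least 6.5-fold higher number from compound 1 to compound 2 (0.81 log units; beyond the scatter). Compound 3 `O=C(Nc1nc2ccc(Cl)cc2s1)c1cn(-c2ccccc2)nc1-c1ccc(F)cc1` gives 3870 nM in this assay; it differs from compound 1 by fluoro in place of hydrogen on an aromatic carbon, a step of a 2.0-fold lower number from compound 1 to compound 3 (0.30 log units; within the scatter). Compound 4 `COc1ccc2nc(NC(=O)c3cn(-c4ccccc4)nc3-c3ccc(F)cc3)sc2c1` has not yet been measured. It differs from compound 3 by methoxy in place of chloro on an aromatic carbon, the same change that was made from compound 1 to compound 2, made here on the core of compound 3. Since that earlier change weakened compound 1 to a limit by an at least 6.5-fold higher number from compound 1 to compound 2 (0.81 log units; beyond the scatter), compound 4 is expected to shift from compound 3 by a 7.8-fold higher number from compound 3 to compound 4 (0.89 log units; beyond the scatter). Compound 4 is therefore estimated at 30000 nM in this assay.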

Compound 4, half-maximal inhibitory concentration: > 50000 nM
Compound 4: a limit, no number; the forecaster's own chance of this, stated with the estimate: 45%; middle value at least 1.6-fold (0.22 log units) from the limit.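

Compound 4 stops at > 50000 nM, which is a limit of this assay and not a number. Methoxy in place of chloro also weakens the fluoro-bearing core, with an at least 12-fold higher number from compound 3 to compound 4 (1.11 log units; beyond the scatter), so the direction of the change carries over between these two cores, but whether its size is the same cannot be told: the same change on two cores in this assay, an at least 6.5-fold higher number (0.81 log units; beyond the scatter) from compound 1 to compound 2 and an at least 12-fold higher number (1.11 log units; beyond the scatter) from compound 3 to compound 4; the limit leaves it open whether they differ. The step between compound 2 and compound 4, fluoro in place of hydrogen, cannot be read: the limit of > 50000 nM in this assay, at which 2 of the 4 values shown sit.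

From the compounds shown here alone, how weak the two methoxy compounds really are stays open, since neither gives a number. Also open, going by these compounds, is how an amine or a carboxylic acid would behave in the place of the chloro on either core.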